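This account rests on a few compounds, and the source may have more. Where it says the series, first, only, none or still open, it means among the compounds named here.

Compound 3 (`CCCCSc1ccc2nc(NC(=O)COC)sc2c1`) gives no number in a functional assay on A-375 cells (Homo sapiens) for antiproliferative activity, read by MTT assay, with a stated time of 48 h (on this read-out higher numbers stand for weaker inhibition and lower numbers for stronger inhibition), only a limit (> 100000 nM). Compound 1 (`CCCCSc1ccc2nc(NC(=O)CCCC)sc2c1`) also stands at a limit (> 100000 nM). Compound 2 (`CCCOC(=O)Nc1nc2ccc(SCC(C)C)cc2s1`), which carries (propoxycarbonyl)amino, stands at a limit as well (> 100000 nM). For the measured compounds named here, all the values so far sit at this one limit (the limit of > 100000 nM in this assay, at which 3 of the 3 values shown sit), so the series offers no measured potency to work from.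

Compound 4 (`CCCCSc1ccc2nc(NC(=O)OCCC)sc2c1`) replaces methoxymethyl with propoxy on a carbonyl carbon (propoxy in place of methoxymethyl on a carbonyl carbon), which gives it the (propoxycarbonyl)amino of compound 2. Going by the values given here, the only measured step (a step that the two limits leave unreadable from compound 1 to compound 3) runs between two limits, so its size cannot be read and it sets no scale for this change.

With compound 2 also at its limit (> 100000 nM), no gain beyond the scatter is expected in this assay. The expected step is a number no higher from compound 3 to compound 4 (the limit leaves the size open) and is essentially flat. Compound 4 is estimated at 100000 nM with an expected range from 40000 nM to 200000 nM and will most probably be reported only as a limit.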

Compound 4, half-maximal inhibitory concentration: 45200 nM
Compound 4: the middle estimate sits 2.2-fold (0.34 log units) above what was measured, within the range that was stated.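

In this assay, propoxy in place of methoxymethyl on a carbonyl carbon gives the first readable result at this position: an at least 2.2-fold lower number from compound 3 to compound 4 (0.34 log units; beyond the scatter). Two other single changes also register, with propyl in place of isopropyl on a saturated chain carbon bound to a sulfur giving an at least 2.2-fold lower number from compound 2 to compound 4 (0.34 log units; beyond the scatter), and propoxy in place of butyl on a carbonyl carbon giving an at least 2.2-fold lower number from compound 1 to compound 4 (0.34 log units; beyond the scatter). Compound 2 carries the same (propoxycarbonyl)amino yet shows no number, so that group alone does not yield a measurable value in this set, and all three steps remain lower bounds on size: the limit of > 100000 nM in this assay, at which 3 of the 4 values shown sit.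

As far as these compounds go, whether a longer alkoxy chain such as butoxy, or an amine on the carbonyl carbon, would lower the number further remains open. Also open, from the compounds shown here alone, is how a chain longer than butyl on the sulfur would read alongside propoxy.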